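The source may hold more compounds than are shown below. What is called first, only, known or untested is meant among the compounds shown, and "the series" means these compounds.

Compound 1 `COc1ccc(C(=O)NNC(=S)Nc2csc(-c3ccccc3)c2)cc1` and compound 2 `COc1ccc(C(=O)NNC(=S)Nc2csc(-c3ccc(C)cc3)c2)cc1` share one core; compound 3 `COc1cc(OC)cc(C(=O)NNC(=S)Nc2csc(-c3ccccc3)c2)c1` and compound 4 `COc1cc(OC)cc(C(=O)NNC(=S)Nc2csc(-c3ccc(C)cc3)c2)c1` share another, and the difference between the two cores is not broken down here. In a functional assay on U-373MG ATCC cells (Homo sapiens) for inhibition, read by colorimetric assay and MTT assay, with a stated time of 72 h (a lower number here means a stronger inhibitor, a higher number a weaker inhibitor), compound 1 gives 41000 nM and compound 2 gives 19000 nM. The change between them, (methyl in place of hydrogen on an aromatic carbon), gave a 2.2-fold lower number from compound 1 to compound 2 (0.33 log units; beyond the scatter). In this assay compound 3 gives 40000 nM; its number and that of compound 1 lie within the usual scatter of each other. Compound 4 carries the same change relative to compound 3, (methyl in place of hydrogen on an aromatic carbon), which thus occurs twice among these four compounds. For the measured compounds named here, for compound 4 a step of the earlier size is expected, a 2.1-fold lower number from compound 3 to compound 4 (0.32 log units; beyond the scatter), since the only precedent is a 2.2-fold lower number from compound 1 to compound 2 (0.33 log units; beyond the scatter). Compound 4 is accordingly estimated at 19000 nM, with a likely range from 9000 nM to 40000 nM.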

Compound 4, half-maximal inhibitory concentration: 41000 nM
Estimate against measurement, compound 4: 2.2-fold (0.33 log units) below; the measured number lies above the stated range.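

In this assay the change of phenyl to 4-methylphenyl gives a 1.0-fold higher number from compound 3 to compound 4 (0.01 log units; within the scatter) on the second core. The two steps cannot be told apart, so these data give no firm sign that the core alters the outcome of this change: the same change on two cores in this assay, a 2.2-fold lower number (0.33 log units; beyond the scatter) from compound 1 to compound 2 and a 1.0-fold higher number (0.01 log units; within the scatter) from compound 3 to compound 4, 2.2-fold (0.34 log units) apart, within the scatter of two such steps. Nor do they show that the change carries over at a fixed size: there is only one pair per core, and one step lies beyond the scatter while the other lies within it.

On these data alone, it remains open whether an amine, a carboxylic acid or a longer chain such as ethyl in that place would give a clearer step on either core. Further pairs on both cores would be needed to settle whether the methyl step depends on the core.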